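A few compounds are considered here, and "the series" means these few. Any claim that something is new, unique, unknown or untested is made for them only; others in the source may bear on it.

Measured so far in an ADME assay on MT4 cells (Homo sapiens) for cytotoxicity, read by spectrophotometry, with a stated time of 5 days; a higher number here means that more compound is tolerated, a lower number that less compound is tolerated:

- compound 1, `CCN(CC)CN1C(=O)/C(=N\NC(=S)NO)c2cc(Cl)ccc21`, gives 562000 nM
- compound 2, `CCN(CC)CN1C(=O)/C(=N\NC(=S)NO)c2cc(F)ccc21`, gives 521000 nM
- compound 3, `O=C1/C(=N\NC(=S)NO)c2cc(Cl)ccc2N1CN1CCN(c2ccccc2)CC1`, gives 273000 nM

Compound 4, `O=C1/C(=N\NC(=S)NO)c2cc(F)ccc2N1CN1CCN(c2ccccc2)CC1`, has not yet been measured in this assay. It differs from compound 3 by fluoro in place of chloro on an aromatic carbon.

The same change has been made once before, from compound 1 to compound 2: fluoro in place of chloro on an aromatic carbon. The two place descriptions agree word for word, so this is the same change on a different core. Its effect in this assay was a 1.1-fold lower number from compound 1 to compound 2 (0.03 log units; within the scatter), a step that does not stand out from repeat-measurement noise.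

Compound 3 carries a different core from compounds 1 and 2; the difference between the two cores is not broken down here. Its value in this assay lies within the usual scatter of the value of compound 2 and just beyond the scatter of the value of compound 1, so the core change itself has, at most, a modest effect on this read-out.

Going by the values given here, for compound 4 in this assay the expected step is a 1.1-fold lower number from compound 3 to compound 4 (0.03 log units; within the scatter), a step of essentially the same size as the earlier one, resting on the single precedent a 1.1-fold lower number from compound 1 to compound 2 (0.03 log units; within the scatter) from compound 1 to compound 2. Among the compounds with values here, with only one prior instance, the expectation is held loosely. Compound 4 is therefore estimated at 255000 nM, with a plausible range from 150000 nM to 450000 nM.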

Compound 4, half-maximal cytotoxic concentration: 251000 nM
Beside the measured number, compound 4's estimate is 1.0-fold (0.01 log units) above it; measured number inside the range.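

In this assay, fluoro in place of chloro on an aromatic carbon gives a 1.1-fold lower number from compound 3 to compound 4 (0.04 log units; within the scatter), and this step can be set beside the one on the core of compound 1: the same change on two cores in this assay, a 1.1-fold lower number (0.03 log units; within the scatter) from compound 1 to compound 2 and a 1.1-fold lower number (0.04 log units; within the scatter) from compound 3 to compound 4, 1.0-fold (0.00 log units) apart, within the scatter of two such steps

On these two cores the change therefore carries over without a visible difference, with both steps small and neither standing out from the usual scatter of repeated measurements. Going by these compounds alone, this agreement is between two steps that are both within the scatter, so it shows only that the exchange leaves this read-out unmoved on both cores, and a larger step that depends on the core would be seen only if one appeared on another core. Two cores are also too few to support a rule for the whole series, and the result says nothing about any read-out other than tolerated concentration in these cells.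

The compounds shown carry only chloro or fluoro at this place on the aromatic ring, so it remains open whether bromo, methoxy, a nitrile or plain hydrogen there would move the number. Also open, from the compounds shown here alone, is whether the same small step holds on a third core, for instance one carrying a carboxylic acid or a longer chain.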